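The source may report more compounds than this note shows. Statements on the series, on what has been measured and on what is new or still open speak of the compounds shown alone.

Compound 1 `CCC(C)(C)Cc1c[nH]c(CCc2ccc(-c3cccc(N)n3)cc2)n1`: 97 nM in a functional assay on HEK293 cells for agonist activity at Bombesin receptor subtype-3 (Homo sapiens), read by luminescence and calcium flux, with a stated time of 10 min; on this read-out lower numbers stand for an effect already at smaller amounts and higher numbers for an effect only at larger amounts of compound
Compound 2 `c1ccc(-c2ccc(CCc3nc(CC4CCCC4)c[nH]3)cc2)nc1`: 98 nM

In this assay compound 1 gives 97 nM, and compound 2 gives 98 nM, the two numbers lying within the scatter of each other, so neither stands apart. Compound 3 `CCC(C)(C)Cc1c[nH]c(CCc2ccc(-c3cccnc3C(=O)O)cc2)n1` differs from compound 1 in one place: 2-carboxypyridin-3-yl in place of 6-aminopyridin-2-yl on an aromatic carbon. Within the data shown here, no measured pair shows such a change, so the step can only be anticipated. The step of a 6.2-fold higher number from compound 1 to compound 3 (0.79 log units; beyond the scatter) is expected to run toward larger amounts of compound 3 being needed, beyond the scatter. Compound 3 is estimated at 600 nM, with a range from 120 nM to 3000 nM.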

Compound 3, half-maximal effective concentration: 95 nM
The estimate for compound 3 lay 6.3-fold (0.80 log units) above the measured number, outside the stated range (below it).
By their numbers in this assay, from the lowest: compounds 3, 1 and 2 (each within the scatter of the next).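

In this assay, placing 2-carboxypyridin-3-yl in place of 6-aminopyridin-2-yl on the aromatic carbon para to a large group gives a 1.0-fold lower number from compound 1 to compound 3 (0.01 log units; within the scatter) and so does not separate the two groups. This position therefore tolerates a carboxylic acid as well as an amine on the pyridine ring, even though the attachment point on that ring differs. Nothing at hand accounts for this outcome.

As far as these compounds go, it remains open whether a methyl ester or a primary amide in place of the carboxylic acid would give a similar number. Also unresolved is how the carboxylic acid would fare at another position on the pyridine ring.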